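Swapping nitro for chloro on a thiadiazole hydrazone series

This account rests on a few compounds, and the source may have more. Where it says the series, first, only, none or still open, it means among the compounds named here.

Measured compounds:
- compound 1, `Cc1nnc(SCC(=O)N/N=c2/scc(-c3ccc([N+](=O)[O-])cc3)n2-c2ccccc2)s1`: "not determined" (no result reported)
- compound 2, `Cn1nnnc1SCC(=O)N/N=c1/scc(-c2ccc([N+](=O)[O-])cc2)n1-c1ccccc1`: > 200 ug/mL
- compound 3, `O=C(CSc1nnnn1-c1ccccc1)N/N=c1/scc(-c2ccc([N+](=O)[O-])cc2)n1-c1ccccc1`: "not determined" (no result reported)

Three compounds share a core and were tested in a functional assay on C6 cells (Rattus norvegicus) for cytotoxicity, read by MTT assay, with a stated time of 24 h; a lower number here means a stronger inhibitor, a higher number a weaker inhibitor. For compound 1 no result was reported in this assay, so it stands without a number of its own. Compound 3 likewise has no reported value. For compound 2 the assay reports only a limit, > 200 ug/mL, not a measured number; this is the limit (the limit of > 200 ug/mL in this assay, at which 1 of the 3 values shown sits). For the measured compounds named here, no step between two measured compounds exists in this set, so nothing can be said about how any single structural change moves the read-out.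

Compound 4, `Cc1nnc(SCC(=O)N/N=c2/scc(-c3ccc(Cl)cc3)n2-c2ccccc2)s1`, has not yet been measured. It differs from compound 1 by chloro in place of nitro on an aromatic carbon. Going by the values given here, with no measured step to lean on, no direction beyond the scatter can be predicted. Given that the one reported entry is a limit, compound 4 is expected to come out weak, estimated at 150 ug/mL, within a range from 40 ug/mL to 400 ug/mL.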

Compound 4, half-maximal inhibitory concentration: 28 ug/mL
Beside the measured number, compound 4's estimate is 5.4-fold (0.73 log units) above it, outside the stated range (below it).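

For the compounds shown here, the result for compound 4 gives no step from compound 1, whose entry in this assay reads "not determined" (no result reported), so the change from 4-nitrophenyl to 4-chlorophenyl cannot be read. The compounds shown leave open how this swap moves the read-out on the shared core.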